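A few compounds are considered here, and "the series" means these few. Any claim that something is new, unique, unknown or untested is made for them only; others in the source may bear on it.

Measured so far in an assay on isolated protein for displacement of a labelled ligand from melanin-concentrating hormone receptor 1 (Homo sapiens); on this read-out lower numbers stand for stronger inhibition and higher numbers for weaker inhibition:
compound 1 `CCCc1cc(N)c2cc(NC(=O)/C=C/c3ccc(N)cc3)ccc2n1`, 190 nM
compound 2 `Nc1cc(C2CCCC2)nc2ccc(NC(=O)/C=C/c3ccc(C(F)(F)F)cc3)cc12`, 0.8 nM
compound 3 `CCCc1cc(OC)c2cc(NC(=O)/C=C/c3ccc(C(F)(F)F)cc3)ccc2n1`, 26 nM

Compound 1 stands at the highest number of the three, above compound 3 and far above compound 2; both gaps lie beyond the scatter. Compounds 2 and 3 each differ from compound 1 in two places, so their values only show that partners other than the 4-aminophenyl group have gone with lower numbers.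

Compound 4 `CCCc1cc(N)c2cc(NC(=O)/C=C/c3ccc(Cl)cc3Cl)ccc2n1` has not yet been measured. It differs from compound 1 in one place: 2,4-dichlorophenyl in place of 4-aminophenyl on a double-bonded chain carbon bound to a double-bonded chain carbon. Given that compound 3 gives 26 nM and compound 1 gives 190 nM, a step toward a lower number, beyond the scatter, is expected, estimated as a 9.5-fold lower number from compound 1 to compound 4 (0.98 log units; beyond the scatter). Compound 4 is expected near 20 nM, within 4 nM to 100 nM.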

Compound 4, half-maximal inhibitory concentration: 6.6 nM
Estimate against measurement, compound 4: 3.0-fold (0.48 log units) above; low and high end bracket the measured number.
By their numbers in this assay, from the lowest: compound 2; then compound 4; then compound 3; then compound 1.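

In this assay, for the compounds shown here, the change from 4-aminophenyl to 2,4-dichlorophenyl gives a 29-fold lower number from compound 1 to compound 4 (1.46 log units; beyond the scatter) and is the first single-place comparison. It shows that this position alone moves the read-out by a large step with the rest of compound 1 held fixed. A low number here does not require the hydrogen-bond donor and acceptor counted on 4-aminophenyl, and no measurement on hand gives a cause for the step.

Going by these compounds, whether both chlorines are needed stays open. So does how a single chlorine, an unsubstituted phenyl or a carboxylic acid would fare at this position.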